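The source may hold more compounds than are shown below. What is called first, only, known or untested is meant among the compounds shown, and "the series" means these compounds.

Measured so far in the study:

Compound 1 `Nc1cnc(-c2cc(N3C[C@@H]4C[C@H]3CO4)nc(N3CC4CC3C4)n2)cn1`: 247 nM
Compound 2 `CCOC(=O)N1C[C@@H]2C[C@H]1CN2c1nc(-c2cnc(N)c(OC(F)F)n2)cc(N2CC3CC2C3)n1`: 13 nM
Compound 3 `CSc1cc(-c2cnc(N)c(OC(F)F)n2)nc(N2C[C@@H]3C[C@H]2CO3)n1`: 45 nM

In an assay on Sf21 cells for inhibition of mitogen-activated protein kinase kinase kinase 13 (Homo sapiens), read by HTRF, with a stated time of 1.5 h (on this read-out higher numbers stand for weaker inhibition and lower numbers for stronger inhibition), compound 1 gives 247 nM, the highest of the three numbers. Compound 3 gives 45 nM and compound 2 gives 13 nM; both numbers lie beyond the scatter from that of compound 1, with compound 2 the furthest away. Among the measured compounds shown here, no pair of measured compounds differs in only one place, so no single-change step is known in this assay.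

Compound 4 `Nc1ncc(-c2cc(N3C[C@@H]4C[C@H]3CO4)nc(N3CC4CC3C4)n2)nc1C(F)(F)F` differs from compound 1 by trifluoromethyl in place of hydrogen on an aromatic carbon. Compounds 2 and 3 both carry a group other than hydrogen ortho to the amino group, and both give lower numbers than compound 1, though their other parts differ too. Against that background a step toward stronger inhibition, beyond the scatter, is expected for compound 4. Compound 4 is expected to give 60 nM in this assay, with a range of 20 nM to 200 nM, an estimated step of a 4.1-fold lower number from compound 1 to compound 4 (0.61 log units; beyond the scatter).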

Compound 4, half-maximal inhibitory concentration: 149 nM
Compound 4: the middle estimate sits 2.5-fold (0.40 log units) below what was measured, and the stated range covers the measured number.
By their numbers in this assay, from the lowest: compound 2; then compound 3; then compounds 4 and 1 (each within the scatter of the next).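

On the core of compound 1, trifluoromethyl in place of hydrogen on an aromatic carbon, next to the ring nitrogen and ortho to an amino group, gives in this assay a step of a 1.7-fold lower number from compound 1 to compound 4 (0.22 log units; within the scatter) and so no separable change. Among the compounds shown here, this is the first single-change step known in this assay, and it shows that this position takes trifluoromethyl without a shift that can be told from the scatter. No measurement on hand offers an explanation for this result.

From the compounds shown here alone, whether a different group at this same position, such as chlorine, methyl or a nitrile, would give a step beyond the scatter on the core of compound 1 remains open. Also open, going by these compounds, is whether trifluoromethyl at this position would give a similar step if the groups elsewhere on the core were different.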